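A few compounds are considered here, and "the series" means these few. Any claim that something is new, unique, unknown or untested is made for them only; others in the source may bear on it.

Measured in a functional assay on CEM-SS cells (Homo sapiens) for cytotoxicity; a lower number here means a stronger inhibitor, a higher number a weaker inhibitor:
- compound 1 `Cc1cccc(Cn2c(N)nc3cc(Cl)c(Cl)cc32)c1` gives 48000 nM
- compound 2 `Clc1cccc(Cn2c(Cl)nc3cc(Cl)c(Cl)cc32)c1` gives > 100000 nM (a limit of the assay, not a number)

Compound 2 thus stands at the limit, with no number to step from. Compound 3 `Cc1cccc(Cn2c(Cl)nc3cc(Cl)c(Cl)cc32)c1` has methyl in place of chloro on an aromatic carbon, meta to a large group (methyl in place of chloro on an aromatic carbon). Within the data shown here, no measured step covers this change. In this assay, among the measured compounds shown here, compound 1, which also carries the methyl, gives 48000 nM as the only number so far. The expected step of an at least 1.3-fold lower number from compound 2 to compound 3 (0.12 log units; that floor lies within the scatter) is small, toward stronger inhibition. Compound 3 is estimated at 75000 nM (expected range 30000 nM to 100000 nM) and may also be reported only as a limit.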

Compound 3, half-maximal inhibitory concentration: > 100000 nM
Compound 3 was reported as a limit; the forecaster's own chance of this, stated with the estimate: 45%; at least 1.3-fold (0.12 log units) between middle value and limit.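

In this assay compound 3 gives > 100000 nM as a limit of the assay and not a number. Among these compounds, the one readable change is chloro in place of amino on an aromatic carbon, which gives an at least 2.0-fold higher number from compound 1 to compound 3 (0.31 log units; beyond the scatter) and leaves compound 1 as the only compound here with a number. Methyl in place of chloro cannot be read, since both compounds sit at the limit: the limit of > 100000 nM in this assay, at which 2 of the 3 values shown sit.

Going by these compounds, whether methyl and chloro differ at this place stays open. Also open, on these data alone, is how a methylamino or hydroxyl group in place of the amino group would read.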